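A few compounds are considered here, and "the series" means these few. Any claim that something is new, unique, unknown or untested is made for them only; others in the source may bear on it.

Series notes, antiproliferative arm. The shared core of compound 1 `O=C(Nc1cccc(-c2oc3cc(-c4ccc(F)cc4)ccc3c(=O)c2O)c1)c1ccccc1F` carries an amide whose acyl part is varied; compound 2 `O=C(Nc1cccc(-c2oc3cc(-c4ccc(F)cc4)ccc3c(=O)c2O)c1)c1ccc(C(F)(F)F)cc1`, compound 3 `Cc1cccc(C(=O)Nc2cccc(-c3oc4cc(-c5ccc(F)cc5)ccc4c(=O)c3O)c2)c1` and the unmeasured compound 4 `Cc1cc(C(=O)Nc2cccc(-c3oc4cc(-c5ccc(F)cc5)ccc4c(=O)c3O)c2)ccc1F` differ from it only there. For the measured compounds named here, in a functional assay on GTL 16 cells for antiproliferative activity against GTL 16 cell line (Homo sapiens), read by CCK-8 assay, with a stated time of 72 h (on this read-out lower numbers stand for stronger inhibition and higher numbers for weaker inhibition), compound 1 gives 17400 nM, the second highest of the three numbers so far. Compound 2 gives 33000 nM and compound 3 gives 10900 nM. The step of a 1.9-fold higher number from compound 1 to compound 2 (0.28 log units; within the scatter) and the step of a 1.6-fold lower number from compound 1 to compound 3 (0.20 log units; within the scatter) are both within the scatter, while a 3.0-fold lower number from compound 2 to compound 3 (0.48 log units; beyond the scatter) is a modest step beyond it, so the acyl aryl group moves this read-out only a little across the three.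

Compound 4 arises from compound 1 by the change (4-fluoro-3-methylphenyl in place of 2-fluorophenyl on a carbonyl carbon). The entering group carries the methyl of compound 3 together with a fluorine; the nearest measured point is compound 3 with 10900 nM. The expectation is therefore a step no larger than a 1.5-fold lower number from compound 1 to compound 4 (0.16 log units; within the scatter), in the direction of compound 3 and likely within the scatter. Compound 4 is estimated at 12000 nM, with a range from 5000 nM to 30000 nM.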

Compound 4, half-maximal inhibitory concentration: 12100 nM
Compound 4: the middle estimate sits 1.0-fold (0.00 log units) below what was measured, and the stated range covers the measured number.
By their numbers in this assay, from the lowest: compounds 3, 4, 1 and 2 (each within the scatter of the next, the first and the last beyond it).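

In this assay, fluoro in place of hydrogen on an aromatic carbon of the 3-methylphenyl group makes no readable difference, a 1.1-fold higher number from compound 3 to compound 4 (0.05 log units; within the scatter), and the 4-fluoro-3-methylphenyl group is likewise level with the 2-fluorophenyl group, a 1.4-fold lower number from compound 1 to compound 4 (0.16 log units; within the scatter). For the compounds shown here, only the comparison with the 4-(trifluoromethyl)phenyl group passes the scatter, a 2.7-fold lower number from compound 2 to compound 4 (0.44 log units; beyond the scatter), which gives a second modest step from compound 2 alongside the one to compound 3, although compound 2 and compound 1 remain within the scatter of each other. Nothing available explains these steps.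

Going by these compounds, whether an acyl part carrying an amine or a carboxylic acid, or a longer alkyl chain in place of the aryl ring, would move this read-out further remains open. On these data alone, all four compounds share one core, so it is also open whether this narrow spread holds with the 4-fluorophenyl group of that core replaced.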